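The source may report more compounds than this note shows. Statements on the series, on what has been measured and on what is new or still open speak of the compounds shown alone.

Working notes on the series. Compound 1 `O=S(=O)(CC1=NCCO1)c1c[nH]cc1S(=O)(=O)c1ccccc1` and compound 2 `O=S(=O)(CC1=NCCS1)c1c[nH]cc1S(=O)(=O)c1ccc(Cl)cc1` share the same core and have both been tested in a functional assay for inhibition, tested at 100 uM; on this read-out higher numbers stand for more inhibition at the one concentration tested (going by the name of the read-out) and lower numbers for less inhibition; in this assay compound 1 gives 87.7%, while compound 2 gives 41.4%. Going by the values given here, compound 2 thus stands lowest of the two numbers so far, and the gap to compound 1 lies beyond the scatter. The two structures differ in more than one place, so no single step can be read from this pair.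

Compound 3 `O=S(=O)(CC1=NCCS1)c1c[nH]cc1S(=O)(=O)c1ccccc1` is not yet measured. It differs from compound 2 in one place: hydrogen in place of chloro on an aromatic carbon. Among the compounds with values here, the phenyl so produced is the one compound 1 carries, but the ring attached through the sulfonylmethyl group is that of compound 2. Within the data shown here, with compound 1 at 87.7% as the only guide, an increase of moderate size, beyond the scatter, is expected for compound 3, namely a step of a number 23.6 percentage points higher from compound 2 to compound 3 (beyond the scatter). Compound 3 is therefore estimated at 65% in this assay, within a range from 40% to 88%.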

Compound 3, a percentage reported as inhibition, at one concentration (the size of the read-out at that concentration, not a potency): 34.6%
For compound 3 the middle estimate is 30.4 percentage points above the measured one; the measured number lies below the stated range.
By their numbers in this assay, from the lowest: compounds 3 and 2 (each within the scatter of the next); then compound 1.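

In this assay, hydrogen in place of chloro on an aromatic carbon, para to a large group, gives a number 6.8 percentage points lower from compound 2 to compound 3 (within the scatter), so 4-chlorophenyl to phenyl makes no readable difference with the sulfur-bearing five-membered ring in place. The change of the five-membered non-aromatic ring on the saturated chain carbon, with sulfur taking the place of oxygen, gives a number 53.1 percentage points lower from compound 1 to compound 3 (beyond the scatter), so this ring emerges as the place where a large step can be read. Nothing measured here accounts for either step.

The compounds shown leave open whether chloro in place of hydrogen would also stay within the scatter when the oxygen-bearing ring is present. Also open, on these data alone, is how a methoxy group at the same aromatic carbon, or an open-chain amine in place of the five-membered ring, would read out.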